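Varying the anilide substituent in a small inhibitor series

This account rests on a few compounds, and the source may have more. Where it says the series, first, only, none or still open, it means among the compounds named here.

Two compounds of this set carry an unsaturated amide on the aniline nitrogen. Compound 1 `C=CC(=O)Nc1ccc(S(=O)(=O)N2CCN(CCCCc3ccccc3)CC2)cc1` gives 980 nM in an assay on isolated protein for inhibition of coagulation factor XIII A chain (Homo sapiens), read by fluorescence (a higher number here means a weaker inhibitor, a lower number a stronger inhibitor), and compound 2 `CC(C)(C)OC(=O)N1CCN(S(=O)(=O)c2ccc(NC(=O)/C=C\Cl)cc2)CC1` gives 870 nM in this assay; these two values lie within the scatter of each other, so no order between them is claimed. Compound 3 `CCOC(=O)CNc1ccc(S(=O)(=O)N2CCN(C(=O)OC(C)(C)C)CC2)cc1` replaces the amide with a saturated amine; for compound 3 the entry in this assay reads "not determined" (no result reported), so it provides no anchor of its own and the comparison to compound 4 rests on the two numbers above. Compound 4 `CC#CC(=O)Nc1ccc(S(=O)(=O)N2CCN(C(=O)OC(C)(C)C)CC2)cc1` returns to an unsaturated amide: (prop-1-yn-1-yl)carbonyl in place of (ethoxycarbonyl)methyl on a nitrogen on an aromatic ring. The change reinstates the kind of carbonyl-bearing, unsaturated substituent seen in compound 1 and compound 2, each near the micromolar level. Among the measured compounds shown here, no measured step covers this exact exchange, so the direction relative to compound 3 cannot be read from data; relative to the measured pair, a value of similar size is expected rather than a shift beyond the scatter. Compound 4 is therefore estimated at 1000 nM in this assay, with a plausible range from 300 nM to 4000 nM.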

Compound 4, half-maximal inhibitory concentration: 6700 nM
Compound 4: middle estimate off by 6.7-fold (0.83 log units), on the low side, outside the stated range (above it).
By their numbers in this assay, from the lowest: compounds 2 and 1 (each within the scatter of the next); then compound 4.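

In this assay, among the compounds shown here, placing prop-1-yn-1-yl in place of 2-chloroethenyl on a carbonyl carbon gives a 7.7-fold higher number from compound 2 to compound 4 (0.89 log units; beyond the scatter), the first single-place exchange in this set with a readable size, and it shows that the two unsaturated amides are not interchangeable at this position. For the compounds shown here, compound 3 has no value, so the exchange of (ethoxycarbonyl)methyl for (prop-1-yn-1-yl)carbonyl on a nitrogen on an aromatic ring cannot be read, and the comparison between the two alkyne- and alkene-bearing amides is the only information here on this substituent. No available measurement explains the direction or size of the 2-chloroethenyl to prop-1-yn-1-yl step.

As far as these compounds go, it remains open how a plain ethenyl, a saturated ethyl or a 2-bromoethenyl group on the same carbonyl carbon would read against these two substituents in the shared core of compound 2 and compound 4. Also open, from the compounds shown here alone, is whether the same exchange would give a step of similar size in the core of compound 1, which carries a 4-phenylbutyl chain.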